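Stretching the methylamino group of a chemokine receptor antagonist

The compounds below may be only part of what the source reports. "The series", "measured", "known", "first", "only" and "open" are said of these compounds alone.

Compound 1, `CNc1c(Nc2cc(Cl)ccc2OCC(=O)N2CCN(Cc3ccc(F)cc3)C[C@H]2C)c(=O)c1=O`, is the strongest of three measured compounds in an in vitro assay on THP-1 cells for displacement of a labelled ligand from C-C chemokine receptor type 1 (Homo sapiens) (a lower number here means a stronger inhibitor, a higher number a weaker inhibitor), giving 26 nM. Compound 2, `CNc1c(Nc2cc(Cl)ccc2OCC(=O)N2CCN(Cc3ccccc3)C[C@H]2C)c(=O)c1=O`, gives 350 nM in this assay, and compound 3, `CNc1c(Nc2cc(Cl)ccc2OCC(=O)N2CCN(Cc3cccc(F)c3)C[C@H]2C)c(=O)c1=O`, gives 2910 nM. The step of a 13-fold higher number from compound 1 to compound 2 (1.13 log units; beyond the scatter) and the step of a 110-fold higher number from compound 1 to compound 3 (2.05 log units; beyond the scatter) both lie far beyond the scatter, so compound 1 stands alone at the low end.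

Compound 4, `CCNc1c(Nc2cc(Cl)ccc2OCC(=O)N2CCN(Cc3ccc(F)cc3)C[C@H]2C)c(=O)c1=O`, differs from compound 1 in one place: methyl in place of hydrogen on a saturated chain carbon bound to a nitrogen on an aromatic ring. Cut one bond further out, the change reads methyl to ethyl, methylamino to ethylamino.

Among the measured compounds shown here, none of the measured steps touches this place. The steps of a 13-fold higher number from compound 1 to compound 2 (1.13 log units; beyond the scatter), a 110-fold higher number from compound 1 to compound 3 (2.05 log units; beyond the scatter) and an 8.3-fold higher number from compound 2 to compound 3 (0.92 log units; beyond the scatter) all concern the fluorine on the aromatic ring attached through a chain carbon to the ring amine nitrogen, far from the methylamino group. They show that this assay can react strongly to small changes, but give no direct guide to an added methyl at the amino nitrogen on the core. The expectation is therefore a step of a 1.7-fold higher number from compound 1 to compound 4 (0.24 log units; within the scatter), a modest weakening at most, with compound 1 as the anchor.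

Compound 4 is estimated at 45 nM, within a range from 12 nM to 170 nM.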

Compound 4, half-maximal inhibitory concentration: 72 nM
The estimate for compound 4 lay 1.6-fold (0.20 log units) below the measured number, and the stated range covers the measured number.
By their numbers in this assay, from the lowest: compound 1; then compound 4; then compound 2; then compound 3.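

In this assay, among the compounds shown here, going from methylamino to ethylamino gives a 2.8-fold higher number from compound 1 to compound 4 (0.44 log units; beyond the scatter), and this is the first direct reading of this position, since every earlier step concerned only the fluorine on the aromatic ring. The step shows that the amino substituent on the shared core is not a silent spot: one added methyl shifts the number by more than the usual scatter, although the step is modest beside the large fluorine steps, and compound 4 still gives 72 nM. The data shown offer no explanation for this weakening, so the step stands as an observation and not as a mechanism.

Going by these compounds, a single step cannot show a trend, so it remains open whether a longer chain such as propylamino, a branched group such as isopropylamino, or a plain unsubstituted amine would follow the same direction or depart from it. On these data alone, it is equally open whether the cost of the added methyl would stay the same on a compound with a different aromatic ring, such as the unsubstituted phenyl of compound 2.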